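A few compounds are considered here, and "the series" means these few. Any claim that something is new, unique, unknown or untested is made for them only; others in the source may bear on it.

Compound 1 `O=C(Nc1cccc(OCc2cn(-c3ccccc3)nn2)c1)Nc1ccc(Cl)c(C(F)(F)F)c1` gives 1780 nM in a functional assay on HepG2 cells (Homo sapiens) for inhibition, read by MTT assay, with a stated time of 72 h; a lower number here means a stronger inhibitor, a higher number a weaker inhibitor; compound 2 `Cc1cccc(-n2cc(COc3cccc(NC(=O)Nc4ccc(Cl)c(C(F)(F)F)c4)c3)nn2)c1` gives 7270 nM in this assay.

In this assay compound 2 stands highest of the two numbers, above compound 1 by the step of a 4.1-fold higher number from compound 1 to compound 2 (0.61 log units; beyond the scatter). Compound 3 `N#Cc1cccc(-n2cc(COc3cccc(NC(=O)Nc4ccc(Cl)c(C(F)(F)F)c4)c3)nn2)c1` differs from compound 2 by cyano in place of methyl on an aromatic carbon. Within the data shown here, no measured step swaps a methyl for a cyano, so only the step from compound 1 to compound 2 gives a sense of the scale this position can move. A step within the scatter is expected, with no direction that can be called, so compound 3 is estimated at 5000 nM, between 1500 nM and 16000 nM, a change of a 1.5-fold lower number from compound 2 to compound 3 (0.16 log units; within the scatter).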

Compound 3, half-maximal inhibitory concentration: 2760 nM
Estimate against measurement, compound 3: 1.8-fold (0.26 log units) above; low and high end bracket the measured number.
By their numbers in this assay, from the lowest: compounds 1 and 3 (each within the scatter of the next); then compound 2.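

Replacing the methyl with a cyano on this ring recovers much of what the methyl cost in this assay (a 2.6-fold lower number from compound 2 to compound 3 (0.42 log units; beyond the scatter)). The position therefore does not respond to every added group in the same way: methyl moved the number beyond the scatter, whereas cyano does not separate compound 3 from the unsubstituted compound 1 (a 1.6-fold higher number from compound 1 to compound 3 (0.19 log units; within the scatter)). Still open, going by these compounds, is how an amine, a carboxylic acid or a longer chain would behave here. No supporting measurement explains why these two groups differ.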